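Moving the methoxy group on a sulfonamide diamine series

This account rests on a few compounds, and the source may have more. Where it says the series, first, only, none or still open, it means among the compounds named here.

Measured so far in a functional assay on PANC-1 cells (Homo sapiens) for inhibition, read by MTT assay, with a stated time of 72 h; on this read-out higher numbers stand for weaker inhibition of growth and lower numbers for stronger inhibition of growth: compound 1 `O=S(=O)(NCCCNCc1ccccc1Cl)c1cc(C(F)(F)F)cc(C(F)(F)F)c1` gives 15000 nM; compound 2 `O=S(=O)(NCCCNCc1ccc(Br)cc1)c1cc(C(F)(F)F)cc(C(F)(F)F)c1` gives 2200 nM; compound 3 `COc1ccc(CNCCCNS(=O)(=O)c2cc(C(F)(F)F)cc(C(F)(F)F)c2)cc1` gives 11000 nM.

Among the compounds with values here, compound 3 has the second highest of the three numbers: its nearest neighbour is compound 1, at a gap within the scatter, and its only step beyond the scatter is a 5.0-fold higher number from compound 2 to compound 3 (0.70 log units; beyond the scatter). Compound 4 `COc1ccccc1CNCCCNS(=O)(=O)c1cc(C(F)(F)F)cc(C(F)(F)F)c1` differs from compound 3 in one way: 2-methoxyphenyl in place of 4-methoxyphenyl on a saturated chain carbon bound to an amine nitrogen. Within the data shown here, the step of a 1.4-fold lower number from compound 1 to compound 3 (0.13 log units; within the scatter) and the step of a 6.8-fold lower number from compound 1 to compound 2 (0.83 log units; beyond the scatter) are the only guides, and they compare different groups at the same chain carbon, so they bear on this change only loosely. He therefore expects at most a small rise, a 1.5-fold higher number from compound 3 to compound 4 (0.16 log units; within the scatter), and estimates compound 4 at 16000 nM, with a range from 6000 nM to 40000 nM.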

Compound 4, concentration for 50% growth inhibition: 12000 nM
Beside the measured number, compound 4's estimate is 1.3-fold (0.12 log units) above it; the measured number falls inside the stated range.
By their numbers in this assay, from the lowest: compound 2; then compounds 3, 4 and 1 (each within the scatter of the next).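

In this assay, 2-methoxyphenyl in place of 4-methoxyphenyl gives a 1.1-fold higher number from compound 3 to compound 4 (0.04 log units; within the scatter) and so leaves no readable effect of moving the methoxy in this pair. Methoxy in place of chloro gives a 1.3-fold lower number from compound 1 to compound 4 (0.10 log units; within the scatter) and likewise separates nothing, whereas 2-methoxyphenyl in place of 4-bromophenyl gives a 5.5-fold higher number from compound 2 to compound 4 (0.74 log units; beyond the scatter) and keeps compound 2 apart from the other three compounds.

On these data alone, whether a nitrile on the aromatic ring or a longer chain in the shared core would match compound 2 stays open. Nothing at hand offers an explanation for these numbers.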